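The compounds below may be only part of what the source reports. "The series", "measured", "known", "first", "only" and "open" are said of these compounds alone.

In a functional assay on B16-F10 cells (Mus musculus) for antiproliferative activity, read by MTT assay, with a stated time of 72 h (on this read-out higher numbers stand for weaker inhibition and lower numbers for stronger inhibition), compound 1 `CCCCCCCCCCNC[C@@H]1OC[C@H](N)[C@@H]1O` gives 29600 nM, and compound 2 `CCCCCCCCCCCCNC[C@@H]1OC[C@H](N)[C@H]1O` gives 58100 nM, so the two sit within the scatter of each other. Compound 3 `CCCCCCCCCCNC[C@@H]1OC[C@H](N)[C@H]1O` gives > 128000 nM, which is a limit and not a number. Compound 4 `CCCCCCCCCNC[C@@H]1OC[C@H](N)[C@@H]1O` differs from compound 1 by hydrogen in place of methyl on a saturated chain carbon, nine bonds along the chain from an amine nitrogen. The closest measured change is hydrogen in place of ethyl, an at least 2.2-fold higher number from compound 2 to compound 3 (0.34 log units; beyond the scatter), although it was seen in the other configuration. The configuration change, an at least 4.3-fold higher number from compound 1 to compound 3 (0.63 log units; beyond the scatter), does not bear on chain length. A modest rise in this assay is expected, a 1.6-fold higher number from compound 1 to compound 4 (0.21 log units; within the scatter), near the edge of the scatter. For compound 4 the estimated value is 48000 nM, with an expected range of 24000 nM to 110000 nM.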

Compound 4, half-maximal inhibitory concentration: 55200 nM
For compound 4 the middle estimate is 1.2-fold (0.06 log units) below the measured one; low and high end bracket the measured number.
By their numbers in this assay, from the lowest: compounds 1, 4 and 2 (each within the scatter of the next). At a limit, above all of these: compound 3.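

In this assay, for the compounds shown here, this is the first chain change read in the configuration of compound 1: hydrogen in place of methyl, nine bonds along the chain from an amine nitrogen, gives a 1.9-fold higher number from compound 1 to compound 4 (0.27 log units; within the scatter). This step cannot be told apart from the scatter of repeated measurements. The earlier chain step, an at least 2.2-fold higher number from compound 2 to compound 3 (0.34 log units; beyond the scatter), lay in the other configuration and rests on a limit: the limit of > 128000 nM in this assay, at which 1 of the 4 values shown sits.

As far as these compounds go, what a much shorter hexyl chain, or a phenyl group in place of the chain, would give on the core of compound 1 stays open.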